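The source may hold more compounds than are shown below. What is called first, only, known or untested is meant among the compounds shown, and "the series" means these compounds.

Working notes on the amide series sharing the core of compound 1 `O=C(Nc1cc(-c2ccccc2)nn1-c1ccccc1)c1ccccc1`.

In an assay on HEK293 cells for displacement of a labelled ligand from metabotropic glutamate receptor 5 (Rattus norvegicus) (on this read-out lower numbers stand for stronger inhibition and higher numbers for weaker inhibition), compound 1 gives 4180 nM. Compound 2 `COc1ccc(C(=O)Nc2cc(-c3ccccc3)nn2-c2ccccc2)cc1` gives 420 nM in this assay. The dinitro analogue compound 3 `O=C(Nc1cc(-c2ccccc2)nn1-c1ccccc1)c1cc([N+](=O)[O-])cc([N+](=O)[O-])c1` was not measured to a number in this assay; its entry reads "not determined" (no result reported), and no result is recorded for it.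

Within the data shown here, compound 2 stands lowest of the two numbers in this assay; the nearest is compound 1, and the step of a 10-fold lower number from compound 1 to compound 2 (1.00 log units; beyond the scatter) is the only measured step in the set.

Compound 4 `Cc1ccc(C(=O)Nc2cc(-c3ccccc3)nn2-c2ccccc2)cc1C` differs from compound 2 by 3,4-dimethylphenyl in place of 4-methoxyphenyl on a carbonyl carbon. Among the measured compounds shown here, no measured step bears directly on this change. The step of a 10-fold lower number from compound 1 to compound 2 (1.00 log units; beyond the scatter) shows that substitution on this aryl amide can move the number well beyond the scatter, but it covers methoxy alone and says nothing about two methyl groups. Compound 4 is therefore expected to land between compound 1 and compound 2, with a modest rise relative to compound 2, a 2.4-fold higher number from compound 2 to compound 4 (0.38 log units; beyond the scatter). The estimate for compound 4 in this assay is 1000 nM, with a range from 250 nM to 4000 nM.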

Compound 4, inhibition constant: 430 nM
Compound 4: middle estimate off by 2.3-fold (0.37 log units), on the high side; the measured number falls inside the stated range.
By their numbers in this assay, from the lowest: compounds 2 and 4 (each within the scatter of the next); then compound 1.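

At this place on the carbonyl carbon, the gain over phenyl is not confined to methoxy: a 9.7-fold lower number from compound 1 to compound 4 (0.99 log units; beyond the scatter) in this assay, so 3,4-dimethylphenyl also moves the number beyond the scatter. Replacing 4-methoxyphenyl with 3,4-dimethylphenyl gives a 1.0-fold higher number from compound 2 to compound 4 (0.01 log units; within the scatter), so across this pair, the loss of the oxygen and its hydrogen-bond acceptor comes with no change beyond the scatter. Nothing on hand explains why these two substituted rings read alike.

The compounds shown do not separate the contributions of the two methyl groups, so a single methyl group on the phenyl ring remains an open comparison. As far as these compounds go, it is also open whether an amine or a carboxylic acid on that ring would keep the number at the level of compound 2 and compound 4.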